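Swapping the aryl group on compound 3's shared core

A few compounds are considered here, and "the series" means these few. Any claim that something is new, unique, unknown or untested is made for them only; others in the source may bear on it.

Compound 3 `COc1cc2c(Oc3ccc(NC(=O)c4cc(-c5ccc(F)cc5)ccn4)cc3F)ccnc2cc1OCCCN1CCN(C)CC1` gives 510 nM in a functional assay on MKN-45 cells (Homo sapiens) for cytotoxicity, read by MTT assay, with a stated time of 72 h (a lower number here means a stronger inhibitor, a higher number a weaker inhibitor), the lowest of the three measured numbers; compound 2 `COc1ccc(-c2ccnc(C(=O)Nc3ccc(Oc4ccnc5cc(OCCCN6CCCCC6)c(OC)cc45)c(F)c3)c2)cc1` gives 570 nM, within the scatter of compound 3, while compound 1 `COc1cc2c(Oc3ccc(NC(=O)c4cc(-c5ccc(F)cc5)ccn4)cc3F)ccnc2cc1OCCCN1CCCCC1` gives 1240 nM. Compound 4 `COc1ccc(-c2ccnc(C(=O)Nc3ccc(Oc4ccnc5cc(OCCCN6CCN(C)CC6)c(OC)cc45)c(F)c3)c2)c(OC)c1` carries 2,4-dimethoxyphenyl in place of 4-fluorophenyl on an aromatic carbon. Going by the values given here, the most telling earlier step is a 2.2-fold lower number from compound 1 to compound 2 (0.34 log units; beyond the scatter), a modest lowering in this assay; the step of a 2.4-fold lower number from compound 1 to compound 3 (0.39 log units; beyond the scatter) concerns the other end of the shared core and does not bear on the new change, and no measured pair shows the effect of the second methoxy group. Compound 4 is therefore expected to follow the pattern of compound 2, with a modest step of about a 2.0-fold lower number from compound 3 to compound 4 (0.29 log units; within the scatter). Compound 4 is estimated at 260 nM, within a range of 100 nM to 700 nM.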

Compound 4, half-maximal inhibitory concentration: 330 nM
Estimate against measurement, compound 4: 1.3-fold (0.10 log units) below; measured number inside the range.
By their numbers in this assay, from the lowest: compounds 4, 3 and 2 (each within the scatter of the next); then compound 1.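

In this assay, putting 2,4-dimethoxyphenyl in place of 4-fluorophenyl opposite the ring nitrogen gives a step that lies within the scatter (a 1.5-fold lower number from compound 3 to compound 4 (0.19 log units; within the scatter)). So, with the 4-methylpiperazin-1-yl group in place, this position takes a second aryl group, carrying two methoxy groups, with no readable change in the number. Nothing shown here explains this result. The compounds leave open what each methoxy group contributes on its own. They also leave open how an amine or a carboxylic acid on this aryl ring would read.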